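The source may hold more compounds than are shown below. What is called first, only, known or untested is meant among the compounds shown, and "the series" means these compounds.

Compound 3 `O=C(CSc1nnc(-c2ccncc2)n1-c1ccccc1)N/N=C/c1ccccc1` gives 18600 nM in a functional assay on HepG2 cells (Homo sapiens) for inhibition, read by MTT assay, with a stated time of 48 h (a lower number here means a stronger inhibitor, a higher number a weaker inhibitor), the higher of the two numbers measured there. Compound 1 `Clc1ccccc1CSc1nnc(-c2ccncc2)n1-c1ccccc1` gives 15700 nM in this assay, within the scatter of compound 3. Compound 2 `Fc1cccc(F)c1CSc1nnc(-c2ccncc2)n1-c1ccccc1` reaches only the limit > 50000 nM in this assay. Within the data shown here, the one measured step, an at least 3.1-fold higher number from compound 1 to compound 2 (0.50 log units; beyond the scatter), is the only one in which fluorine enters an aromatic ring, and it also removed a chlorine, so it bears on the present change only loosely. Compound 4 `O=C(CSc1nnc(-c2ccncc2)n1-c1ccccc1)N/N=C/c1cccc(F)c1` differs from compound 3 by fluoro in place of hydrogen on an aromatic carbon. Compound 4 is therefore expected to give about 24000 nM in this assay, with a range of 9000 nM to 60000 nM. The expected step is a 1.3-fold higher number from compound 3 to compound 4 (0.11 log units; within the scatter), which stays within the scatter.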

Compound 4, half-maximal inhibitory concentration: 24400 nM
Compound 4: the middle estimate sits 1.0-fold (0.01 log units) below what was measured, and the stated range covers the measured number.
By their numbers in this assay, from the lowest: compounds 1, 3 and 4 (each within the scatter of the next). At a limit, above all of these: compound 2.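

In this assay, this change brings fluoro onto an aromatic ring with no chlorine leaving, so phenyl to 3-fluorophenyl, meta to a large group, can be read on its own. That step, a 1.3-fold higher number from compound 3 to compound 4 (0.12 log units; within the scatter), does not separate the pair, so this single fluoro at this position has no effect that can be told from the scatter. Compound 2, by contrast, stands only at a limit of the assay, not at a number: the limit of > 50000 nM in this assay, at which 1 of the 4 values shown sits.

From the compounds shown here alone, whether a chlorine, an amine or a carboxylic acid in place of this fluoro would stand apart from the phenyl parent remains open.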